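The source may report more compounds than this note shows. Statements on the series, on what has been measured and on what is new or still open speak of the compounds shown alone.

Measured so far in a functional assay on DU-145 cells (Homo sapiens) for inhibition, read by trypan blue exclusion, with a stated time of 96 h; a lower number here means a stronger inhibitor of growth, a higher number a weaker inhibitor of growth:
compound 1 `O=C(/C(=C\c1cc(Cl)cc(Cl)c1Cl)S(=O)(=O)Cc1ccc(Cl)cc1)c1ccc(Br)cc1` gives 1000 nM
compound 2 `COc1ccc(/C=C(\C(=O)c2ccc(Br)cc2)S(=O)(=O)Cc2ccc(Cl)cc2)cc1` gives 25000 nM
compound 3 `COc1ccc(/C=C(\C(=O)c2ccc(Br)cc2)S(=O)(=O)Cc2ccc(F)cc2)cc1` gives 25000 nM

Compound 2, at 25000 nM, stands level with compound 3, and together they hold the highest number of the three. Compound 4 `COc1ccsc1/C=C(\C(=O)c1ccc(Br)cc1)S(=O)(=O)Cc1ccc(Cl)cc1` has no number yet in this assay and differs from compound 2 as follows: 3-methoxythiophen-2-yl in place of 4-methoxyphenyl on a double-bonded chain carbon bound to a double-bonded chain carbon, with 3-methoxythiophen-2-yl in place of 4-methoxyphenyl on a double-bonded chain carbon bound to a double-bonded chain carbon.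

Among the measured compounds shown here, two measured steps bear on this. The step of a 25-fold higher number from compound 1 to compound 2 (1.40 log units; beyond the scatter) is a large one at that same place, so the number can move strongly there, although it involves a very different group. The step of no change at the digits printed from compound 2 to compound 3 (within the scatter) is a change elsewhere and says little about this one. For the measured compounds named here, no measured compound carries the new group, so only a modest shift towards a lower number is expected, and the estimated step is a 2.1-fold lower number from compound 2 to compound 4 (0.32 log units; beyond the scatter), a loose expectation. For compound 4 the estimate is 12000 nM, with an expected range from 2500 nM to 40000 nM as its bounds.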

Compound 4, concentration for 50% growth inhibition: 50000 nM
Estimate against measurement, compound 4: 4.2-fold (0.62 log units) below; the measured number lies above the stated range.
By their numbers in this assay, from the lowest: compound 1; then compounds 2, 3 and 4 (each within the scatter of the next).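

At the double-bonded chain carbon, 3-methoxythiophen-2-yl in place of 4-methoxyphenyl gives a 2.0-fold higher number from compound 2 to compound 4 (0.30 log units; within the scatter) in this assay, so this assay does not tell the five-membered ring with its sulfur from the six-membered carbon ring when each carries a methoxy group. Against the 2,3,5-trichlorophenyl group, the same new group gives a 50-fold higher number from compound 1 to compound 4 (1.70 log units; beyond the scatter), which shows that a large step at this place does not depend on the 4-methoxyphenyl group alone. Nothing measured on these compounds gives a reason for either step.

The compounds shown leave open whether the large gap to compound 1 rests on the chloro groups, on the methoxy group, or on both. From the compounds shown here alone, how a plain thiophen-2-yl, or a ring carrying an amine or a carboxylic acid, would read at this place also remains open.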